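Amidrazone thiosemicarbazides: expectation for the thiomorpholine analogue

The compounds below may be only part of what the source reports. "The series", "measured", "known", "first", "only" and "open" are said of these compounds alone.

Measured so far:
compound 1 `Cc1cccc(/C(N)=N/NC(=S)N2CCN(c3ccccn3)CC2)n1` gives 72.7% in a functional assay on HeLa cells (Homo sapiens) for cytotoxicity, read by MTT assay, with a stated time of 72 h, tested at 3 uM; on this read-out higher numbers stand for more inhibition of growth at the one concentration tested and lower numbers for less inhibition of growth
compound 2 `N/C(=N\NC(=S)N1CCCC1)c1ccc(F)cn1` gives 77.7% in this assay
compound 3 `Cc1cccc(/C(N)=N/NC(=S)N2CCSCC2)n1` gives 54.6% in this assay

Compound 2 holds the highest of the three numbers in this assay; compound 1 sits within the scatter of it, while compound 3 lies beyond the scatter below it. Compound 4 `N/C(=N\NC(=S)N1CCSCC1)c1ccc(F)cn1` is not yet measured and differs from compound 2 by thiomorpholin-4-yl in place of pyrrolidin-1-yl on a thiocarbonyl carbon. No step between measured compounds is shown, so the change is judged only on the values themselves. Compound 3 also carries thiomorpholin-4-yl on its thiocarbonyl carbon and gives a number beyond the scatter below compound 2; on that basis a downward step beyond the scatter is expected from compound 2 to compound 4, a number 19.7 percentage points lower from compound 2 to compound 4 (beyond the scatter). Compound 4 is therefore estimated to give 58%, with a range from 42% to 74%.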

Compound 4, percent growth inhibition at one concentration: 62.9%
For compound 4 the middle estimate is 4.9 percentage points below the measured one; the measured number falls inside the stated range.
By their numbers in this assay, from the lowest: compounds 3, 4, 1 and 2 (each within the scatter of the next, the first and the last beyond it).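

In this assay, among the compounds shown here, thiomorpholin-4-yl in place of pyrrolidin-1-yl on a thiocarbonyl carbon gives a number 14.8 percentage points lower from compound 2 to compound 4 (beyond the scatter) as the first change confined to one place. For the compounds shown here, this position therefore responds to the ring it carries, which the earlier compounds, differing in more than one place, could not show directly. Nothing available bears on the cause of this step.

Open, from the compounds shown here alone, is whether ring size or the ring sulfur accounts for the step. Piperidin-1-yl or morpholin-4-yl on the core of compound 2 would separate the two.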